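A few compounds are considered here, and "the series" means these few. Any claim that something is new, unique, unknown or untested is made for them only; others in the source may bear on it.

Working notes on the series. In an ADME assay on J774 cells (Mus musculus) for antiproliferative activity, with a stated time of 72 h (on this read-out higher numbers stand for an effect only at larger amounts of compound and lower numbers for an effect already at smaller amounts), compound 1 `CCc1c(C)[nH]c2cc(OCCOc3ccccc3)c(Br)cc2c1=O` gives only a limit, > 25000 nM. Among the measured compounds shown here, compound 2 `CCCCc1cc2c(=O)c(-c3ccncc3)c(C)[nH]c2cc1OCCOc1ccccc1` gives 23000 nM in this assay, and this is the only actual number so far, so there is no measured step to calibrate against. Compound 3 `CCCCc1cc2c(=O)c(-c3ccc(C(F)(F)F)cc3C)c(C)[nH]c2cc1OCCOc1ccccc1` shares its core with compound 2 and differs in one group: 2-methyl-4-(trifluoromethyl)phenyl in place of pyridin-4-yl on an aromatic carbon. In words, 2-methyl-4-(trifluoromethyl)phenyl stands in place of pyridin-4-yl on an aromatic carbon. For the measured compounds named here, no measured pair covers this exchange, so the expectation rests on the standing of compound 2 at 23000 nM alone. An estimated 1.5-fold lower number from compound 2 to compound 3 (0.19 log units; within the scatter) is expected, a small move towards lower numbers that need not exceed the usual scatter, and a reading reported only as a limit remains possible. For compound 3 the estimate is 15000 nM, with an expected range of 4000 nM to 30000 nM.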

Compound 3, half-maximal effective concentration: 20000 nM
The estimate for compound 3 lay 1.3-fold (0.12 log units) below the measured number; the measured number falls inside the stated range.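

Among the compounds shown here, exchanging pyridin-4-yl for 2-methyl-4-(trifluoromethyl)phenyl gives the first measured step at this position in this assay: a 1.2-fold lower number from compound 2 to compound 3 (0.06 log units; within the scatter). On this aromatic carbon, the loss of the ring nitrogen with its hydrogen-bond acceptor and the entry of a larger carbon-only aryl group therefore leave the read-out within the scatter. Compound 1 gives only a limit, which sets the one other reference point in this assay: the limit of > 25000 nM in this assay, at which 1 of the 3 values shown sits.

Going by these compounds, whether any group at this position can move the number beyond the scatter stays open, as a single step covers only these two aryl groups, and an aminomethyl or carboxylic acid substituent on the aryl ring would test this further. Compound 1 differs from compound 2 and compound 3 in more than one place, so the roles of the butyl chain and the bromine remain unresolved.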